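Nitro in place of methyl in compound 3

The compounds below may be only part of what the source reports. "The series", "measured", "known", "first", "only" and "open" are said of these compounds alone.

In a functional assay on A549/CDDP cells (Homo sapiens) for antiproliferative activity, read by MTT assay, with a stated time of 72 h (on this read-out lower numbers stand for stronger inhibition and higher numbers for weaker inhibition), compound 3 (`Cc1ccc(/C=C/C(=O)/C=C/c2nc(C)c(C)nc2C)cc1`) gives 3990 nM, within the scatter of both compound 1 (`COc1ccc(/C=C/C(=O)/C=C/c2nc(C)c(C)nc2C)cc1`) at 3610 nM and compound 2 (`Cc1nc(C)c(/C=C/C(=O)/C=C/c2ccc(Cl)cc2)nc1C`) at 7490 nM. Compound 4 (`Cc1nc(C)c(/C=C/C(=O)/C=C/c2ccc([N+](=O)[O-])cc2)nc1C`) has nitro in place of methyl on an aromatic carbon. Exchanges on that carbon gave a 1.1-fold higher number from compound 1 to compound 3 (0.04 log units; within the scatter) and a 1.9-fold lower number from compound 2 to compound 3 (0.27 log units; within the scatter), while the largest, a 2.1-fold higher number from compound 1 to compound 2 (0.32 log units; beyond the scatter), was modest. Among the measured compounds shown here, no nitro compound has been measured, so the range stays wide. In this assay, for the measured compounds named here, no step clearly beyond the scatter is expected, with a slight lean towards a higher number, following compound 2 at 7490 nM. The expected step is a 1.3-fold higher number from compound 3 to compound 4 (0.10 log units; within the scatter). The estimate for compound 4 is 5000 nM, with an expected range of 2200 nM to 11000 nM.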

Compound 4, half-maximal inhibitory concentration: 7900 nM
Compound 4: the middle estimate sits 1.6-fold (0.20 log units) below what was measured, within the range that was stated.
By their numbers in this assay, from the lowest: compounds 1, 3, 2 and 4 (each within the scatter of the next, the first and the last beyond it).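

In this assay, nitro on this aromatic carbon, para to a large group, behaves like chloro, with a 1.1-fold higher number from compound 2 to compound 4 (0.02 log units; within the scatter), and the step from methoxy, a 2.2-fold higher number from compound 1 to compound 4 (0.34 log units; beyond the scatter), is again beyond the scatter but modest. Against methyl, the exchange gives a 2.0-fold higher number from compound 3 to compound 4 (0.30 log units; within the scatter), so it does not separate the two groups. Across all four groups at this carbon, no step exceeds a modest size.

No available data bear on why these groups compare as they do. As far as these compounds go, whether an amine or a carboxylic acid on this carbon would stay within the same narrow span remains open.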